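The compounds below may be only part of what the source reports. "The series", "measured", "known", "first", "only" and "open" are said of these compounds alone.

Measured compounds:
Compound 1, `C[C@@H](NC(=O)Nc1ccc(C(C)(C)C)cc1)c1ccccc1`, giving 53% in an ADME assay on the whole organism with Oryza sativa as the target, tested at 10 uM; a higher number here means a weaker effect of the compound at the concentration tested, a lower number a stronger effect.
Compound 2, `C[C@@H](NC(=O)Nc1ccc(C(F)(F)F)cc1)c1ccccc1`, giving 82% in this assay.

Of these two, compound 2 holds the higher number, with compound 1 standing a number 29 percentage points higher from compound 1 to compound 2 (beyond the scatter) as its nearest neighbour. Compound 3, `C[C@@H](NC(=O)Nc1ccc(F)cc1)c1ccccc1`, is not yet measured. It differs from compound 2 by fluoro in place of trifluoromethyl on an aromatic carbon.

Among the measured compounds shown here, only one measured step exists, a number 29 percentage points higher from compound 1 to compound 2 (beyond the scatter), and it concerns a different exchange at the same aromatic carbon, so it bears on the new change only loosely. For the measured compounds named here, no measured pair shows what removing three fluorines from that position does. Compound 3 is therefore expected to move by a number 12 percentage points lower from compound 2 to compound 3 (beyond the scatter) in this assay, a small shift at most and possibly none beyond the scatter. The estimate for compound 3 is 70%, with a range from 50% to 92%.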

Compound 3, a percentage reported as activity, at one concentration (the size of the read-out at that concentration, not a potency): 92%
The estimate for compound 3 lay 22 percentage points below the measured number; low and high end bracket the measured number.
By their numbers in this assay, from the lowest: compound 1; then compounds 2 and 3 (each within the scatter of the next).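

In this assay, fluoro in place of trifluoromethyl on this aromatic carbon gives a number 10 percentage points higher from compound 2 to compound 3 (within the scatter), so the step from four heavy atoms to one does not separate compound 2 from compound 3. Fluoro in place of tert-butyl gives a number 39 percentage points higher from compound 1 to compound 3 (beyond the scatter), a large step that shows compound 1 standing apart from both fluorine-bearing compounds, with the lowest number and so the strongest effect at the concentration tested. Nothing available explains why tert-butyl stands apart here. Open, from the compounds shown here alone, is what an amine, a carboxylic acid or a longer chain such as n-butyl would give on this carbon, and so whether tert-butyl is an isolated case. Also open, going by these compounds, is whether the same picture would hold with these groups elsewhere on the ring.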